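The compounds below may be only part of what the source reports. "The series", "measured", "known", "first", "only" and "open" are said of these compounds alone.

Compound 1 (`C[C@@H](O)[C@H]1C(=O)N2C(C(=O)OCOC(=O)C3CCCCC3)=C(S[C@@H]3CN[C@H](C(=O)Nc4cccc(C(=O)O)c4)C3)[C@H](C)[C@H]12`) : in an ADME assay for metabolic stability, read by LC-MS, with a stated time of 3 h, at pH 6.5, tested at 50 uM (on this read-out higher numbers stand for a more stable compound and lower numbers for a less stable compound), compound 1 gives > 95%, which is a limit of the assay and not a number.
Compound 2 (`CCCOC(=O)C1=C(S[C@@H]2CN[C@H](C(=O)Nc3cccc(C(=O)OCCC)c3)C2)[C@H](C)[C@@H]2[C@@H]([C@@H](C)O)C(=O)N12`) : in this read-out compound 2 gives > 95%, again a limit of the assay.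
Compound 3 (`C[C@@H](O)[C@H]1C(=O)N2C(C(=O)OCOC(=O)C3CCCCC3)=C(S[C@@H]3CN[C@H](C(=O)Nc4cccc(C(=O)OCOC(=O)C5CCCCC5)c4)C3)[C@H](C)[C@H]12`) : in this read-out compound 3 gives > 95%, also a limit of the assay.

Compound 1 therefore stands only at a limit, and so do the two companions, all three sitting at the limit of > 95% in this assay, at which 3 of the 3 values shown sit. Within the data shown here, the single measured step that changes one place is a step that the two limits leave unreadable from compound 1 to compound 3, and the two limits leave its size unreadable. Compound 4 is `CC(C)OC(=O)C1=C(S[C@@H]2CN[C@H](C(=O)Nc3cccc(C(=O)O)c3)C2)[C@H](C)[C@@H]2[C@@H]([C@@H](C)O)C(=O)N12`; against compound 1 it shows (isopropyl in place of ((cyclohexylcarbonyl)oxy)methyl on an oxygen next to a carbonyl group). Among the measured compounds shown here, no measured step touches this change directly, and the unreadable step gives no size to lean on. The expectation is that a step that the limit leaves unreadable from compound 1 to compound 4 amounts to no step beyond the scatter, since compound 1 already sits at the limit (the limit of > 95% in this assay, at which 3 of the 3 values shown sit). Compound 4 is thus estimated at 96%, within a range from 86% to 100%.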

Compound 4, percent of the compound remaining: > 95%
Compound 4 ended at the assay's limit (the forecaster's own chance of this, stated with the estimate: 70%); the middle value is on the limit's open side.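

In this assay compound 4 sits at the same limit as compound 1, so the change between these two compounds has no readable size: the limit of > 95% in this assay, at which 4 of the 4 values shown sit.

The compounds shown leave open how isopropyl and ((cyclohexylcarbonyl)oxy)methyl would compare in this assay, with every value a limit and none a number.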